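Swapping the amide-bound ring in a chromone series

A few compounds are considered here, and "the series" means these few. Any claim that something is new, unique, unknown or untested is made for them only; others in the source may bear on it.

Of the compounds shown here, three that share one core have been tested in a functional assay on HeLa cells (Homo sapiens) for inhibition, read by MTT assay, with a stated time of 48 h; a higher number here means a weaker inhibitor, a lower number a stronger inhibitor. Compound 1 `COc1ccc2c(=O)c(/C=C/C(=O)NCc3ccccc3)coc2c1` carries a benzyl group on the amide-type nitrogen and in this assay gives 33400 nM. Compound 2 `COc1ccc2c(=O)c(/C=C/C(=O)Nc3ccccc3)coc2c1` has a phenyl group there instead; its result in this assay is a limit of the measurement rather than a number, > 100000 nM. Compound 3 `COc1ccc2c(=O)c(/C=C/C(=O)Nc3cc(C)ccc3C)coc2c1` carries a 2,5-dimethylphenyl group and in this assay gives 58400 nM, the highest of the two numbers recorded, with compound 1 nearest to it: a 1.7-fold higher number from compound 1 to compound 3 (0.24 log units; within the scatter).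

The measured steps show that moving the ring directly onto the nitrogen matters: an at least 2.9-fold higher number from compound 1 to compound 2 (0.47 log units; beyond the scatter). Adding two methyl groups to that ring then brings the value back into the measurable range: an at least 1.7-fold lower number from compound 2 to compound 3 (0.23 log units; that floor lies within the scatter).

Compound 4 `COc1cccc(NC(=O)/C=C/c2coc3cc(OC)ccc3c2=O)c1` is not yet measured. It differs from compound 3 as follows: 3-methoxyphenyl in place of 2,5-dimethylphenyl on an amide-type nitrogen. Like compounds 2 and 3 it is an anilide, and a single substituent on the ring is a middle case between the bare phenyl of compound 2 and the twice-substituted ring of compound 3. A small rise or no change beyond the scatter is therefore expected, a 1.2-fold higher number from compound 3 to compound 4 (0.08 log units; within the scatter). The expected value for compound 4 in this assay is 70000 nM, estimated to fall between 30000 nM and 150000 nM.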

Compound 4, half-maximal inhibitory concentration: 19200 nM
Estimate against measurement, compound 4: 3.6-fold (0.56 log units) above, outside the stated range (below it).
By their numbers in this assay, from the lowest: compounds 4, 1 and 3 (each within the scatter of the next, the first and the last beyond it). At a limit, above all of these: compound 2.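

In this assay, the step of a 3.0-fold lower number from compound 3 to compound 4 (0.48 log units; beyond the scatter) shows that on this amide-type nitrogen the identity of the ring's substituents counts, not just whether the ring has any: 2,5-dimethylphenyl and 3-methoxyphenyl have the same heavy-atom count, yet their results differ beyond the scatter. Placing methoxy on the bare phenyl ring gives a step that also lies beyond the scatter, an at least 5.2-fold lower number from compound 2 to compound 4 (0.71 log units; beyond the scatter), so a single added group is enough to bring the value of this anilide into the measurable range. With a 1.7-fold lower number from compound 1 to compound 4 (0.24 log units; within the scatter), the anilide compound 4 cannot be told apart from the benzyl amide compound 1, so a ring bound directly to the nitrogen does not on its own rule out a value like that of the benzyl compound, although compound 2 looked as if it might.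

On these data alone, the full size of the step from the bare phenyl ring stays open, as compound 2 is recorded only as a limit of the assay: the limit of > 100000 nM in this assay, at which 1 of the 4 values shown sits. Also open is how an amine or a carboxylic acid in place of the methoxy on this ring would behave in this assay.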